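This account rests on a few compounds, and the source may have more. Where it says the series, first, only, none or still open, it means among the compounds named here.

Measured compounds:
compound 1, `FC(F)(F)c1ccc(/C=C/[C@@H]2CCCCN2)cc1`, 2.82 ug/mL in a functional assay on A549 cells (Homo sapiens) for inhibition, read by MTT assay, with a stated time of 24 h; a higher number here means a weaker inhibitor, a lower number a stronger inhibitor;
compound 2, `O=[N+]([O-])c1ccc(/C=C/[C@@H]2CCCCN2)cc1`, 3.27 ug/mL in this assay;
compound 3, `C(=C/[C@@H]1CCCCN1)\c1ccccc1`, 9.99 ug/mL in this assay.

Compound 3 carries the highest number of the three in this assay: its nearest neighbour is compound 2, whose number is lower by a 3.1-fold higher number from compound 2 to compound 3 (0.49 log units; beyond the scatter) read the other way round, and compound 1 is further off still, by a 3.5-fold higher number from compound 1 to compound 3 (0.55 log units; beyond the scatter) read in reverse. Both steps lie beyond the scatter.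

Compound 4, `Cc1ccc(/C=C/[C@@H]2CCCCN2)cc1`, differs from compound 3 by methyl in place of hydrogen on an aromatic carbon. Among the measured compounds shown here, the steps that bear on this change are the two in which a group on that same aromatic carbon is replaced by hydrogen: a 3.5-fold higher number from compound 1 to compound 3 (0.55 log units; beyond the scatter) and a 3.1-fold higher number from compound 2 to compound 3 (0.49 log units; beyond the scatter). In both, removing the group gave a modestly higher number; neither group resembles methyl closely, so the size of the effect for compound 4 is uncertain. Compound 4 is therefore expected to show a lower number than compound 3 by a 2.0-fold lower number from compound 3 to compound 4 (0.30 log units; within the scatter). Compound 4 is estimated at 5 ug/mL, with a range of 2.5 ug/mL to 12 ug/mL.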

Compound 4, half-maximal inhibitory concentration: 8.56 ug/mL
For compound 4 the middle estimate is 1.7-fold (0.23 log units) below the measured one; the measured number falls inside the stated range.
By their numbers in this assay, from the lowest: compounds 1 and 2 (each within the scatter of the next); then compounds 4 and 3 (each within the scatter of the next).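

In this assay, methyl in place of hydrogen on this aromatic carbon gives a 1.2-fold lower number from compound 3 to compound 4 (0.07 log units; within the scatter), so not every group placed here separates from hydrogen beyond the scatter. Methyl instead falls apart from the other two groups: nitro replaced by methyl gives a 2.6-fold higher number from compound 2 to compound 4 (0.42 log units; beyond the scatter), and trifluoromethyl replaced by methyl gives a 3.0-fold higher number from compound 1 to compound 4 (0.48 log units; beyond the scatter). Among these four compounds, the position therefore divides into two tiers, with nitro and trifluoromethyl in one and hydrogen and methyl in the other.

No measurement offered here explains this division. The compounds shown also leave open where an amine, a methoxy group or a chlorine atom on this same carbon would fall, and whether a longer chain would stay level with methyl.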